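This account rests on a few compounds, and the source may have more. Where it says the series, first, only, none or still open, it means among the compounds named here.

Working notes on the series. Compound 1 `Nc1nc(N)c2c(-c3ccoc3)cn([C@@H]3O[C@H](CO)[C@@H](O)[C@H]3O)c2n1` carries a furan-3-yl group on the shared core. In a functional assay on HCT-116 cells (Homo sapiens), read by MTT assay, with a stated time of 72 h (a higher number here means a weaker inhibitor, a lower number a stronger inhibitor), compound 1 gives only a limit of the assay, > 20000 nM, and no number. Compound 2 `COc1ncnc2c1c(-c1ccccc1)cn2[C@@H]1O[C@H](CO)[C@@H](O)[C@H]1O` likewise gives only a limit in this assay, > 20000 nM. For the measured compounds named here, compound 3 `C#Cc1cn([C@@H]2O[C@H](CO)[C@@H](O)[C@H]2O)c2ncnc(N(C)C)c12` gives 290 nM in this assay, the single numerical value among the three measured compounds. Compound 1 therefore stands at the limit of the assay, and the limit of > 20000 nM in this assay, at which 2 of the 3 values shown sit, shows that two of the three values sit there, so compound 1 is not separated from compound 2 and is weaker than compound 3 by an amount that cannot be stated.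

Compound 4 `Nc1nc(N)c2c(-c3ccccc3)cn([C@@H]3O[C@H](CO)[C@@H](O)[C@H]3O)c2n1` differs from compound 1 by a single change: phenyl in place of furan-3-yl on an aromatic carbon. Going by the values given here, no step between two measured compounds rests on this change alone; compound 2 carries phenyl as well but differs from compound 4 elsewhere in the core and gives only a limit. Starting from a limit, no step beyond the scatter is expected in this assay: a step that the limit leaves unreadable from compound 1 to compound 4. Compound 4 is expected to give 25000 nM, within a range from 8000 nM to 80000 nM, and will most probably again be reported as a limit.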

Compound 4, half-maximal inhibitory concentration: > 20000 nM
Compound 4: a limit, no number (the forecaster's own chance of this, stated with the estimate: 70%); the middle value is on the limit's open side.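

In this assay, compound 4 gives only a limit of the assay, > 20000 nM, and no number. No step can be read between compound 1 and compound 4, because both stand at the same limit: the limit of > 20000 nM in this assay, at which 3 of the 4 values shown sit.

The compounds shown leave open whether phenyl and furan-3-yl differ at all in their effect on this core.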